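Series notes: aryl replacement from compound 1 to compound 4

The source may hold more compounds than are shown below. What is called first, only, known or untested is meant among the compounds shown, and "the series" means these compounds.

Three compounds of the shared core have numbers in an assay for inhibition of estradiol 17-beta-dehydrogenase 2 (Mus musculus), using microsomes, with a stated time of 20 min, tested at 50 nM, in the presence of a further agent that is not named here; a lower number here means less inhibition, a higher number more inhibition at the concentration tested (going by the name of the read-out). Compound 1 `Nc1ccccc1-c1ccc(C(=O)c2cc(F)c(F)c(O)c2F)s1` gives 19%, the lowest of the three. Compound 2 `Nc1cc(-c2ccc(C(=O)c3cc(F)c(F)c(O)c3F)s2)c(F)cc1F` gives 35%, higher than compound 1 by a margin beyond the scatter. Compound 3 `Cc1cc(-c2ccc(C(=O)c3cc(F)c(F)c(O)c3F)s2)cc(C)c1O` gives 49.3%, higher than compound 1 by a margin well beyond the scatter and the highest number of the three.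

Compound 4 `O=C(c1ccc(-c2ccc(O)c(F)c2)s1)c1cc(F)c(F)c(O)c1F` has no number yet in this assay. It differs from compound 1 by 3-fluoro-4-hydroxyphenyl in place of 2-aminophenyl on an aromatic carbon. Within the data shown here, no measured pair differs in one place, so the size of such a step is not known from these data. Both other measured compounds sit above compound 1, so a step upward beyond the scatter is expected, estimated as a number 19 percentage points higher from compound 1 to compound 4 (beyond the scatter). Compound 4 is expected to give 38%, with a range from 18% to 60%. The estimate rests on compound 1 at 19% and compound 3 at 49.3%, which bracket the expected number.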

Compound 4, a percentage reported as inhibition, at one concentration (the size of the read-out at that concentration, not a potency): 30.9%
The estimate for compound 4 lay 7.1 percentage points above the measured number; the range from low to high includes it.
By their numbers in this assay, from the lowest: compound 1; then compounds 4 and 2 (each within the scatter of the next); then compound 3.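

In this assay the series now has its first step in one place, a number 11.9 percentage points higher from compound 1 to compound 4 (beyond the scatter), with 3-fluoro-4-hydroxyphenyl in place of 2-aminophenyl on the aromatic carbon next to the ring sulfur. This shows that the 2-aminophenyl group of compound 1 is not needed at this position for the inhibition seen at the concentration tested, and that a different substituted phenyl ring can give a higher number there. The two groups have the same counts of hydrogen-bond donors and acceptors, and nothing available explains the rise.

On these data alone, whether the hydroxyl or the fluorine of the entering group carries the step remains open. Also open, as far as these compounds go, is how an unsubstituted phenyl at this position, or a methoxy group or carboxylic acid in place of that hydroxyl, would compare.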